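The source may report more compounds than this note shows. Statements on the series, on what has been measured and on what is new or still open speak of the compounds shown alone.

Compound 3 `COc1ccc(Oc2ccccc2-c2ccsc2S(=O)(=O)N2CCN(C(=S)Nc3ccc(Cl)cc3)CC2)cc1OC` holds the lowest of the three numbers in an assay for binding affinity to Apoptosis regulator Bcl-2 (Homo sapiens), read by fluorescence polarization, with stated times of 30 min and 20 min, tested at 100 uM (a higher number here means more inhibition at the concentration tested (going by the name of the read-out), a lower number less inhibition), where compound 3 gives 18%. Compound 1 `O=C(Nc1cccc([N+](=O)[O-])c1)N1CCN(S(=O)(=O)c2sccc2-c2ccccc2Oc2ccc(O)c(O)c2)CC1` gives 30% and compound 2 `O=C(Nc1ccc([N+](=O)[O-])cc1)N1CCN(S(=O)(=O)c2sccc2-c2ccccc2Oc2ccc(O)c(O)c2)CC1` gives 33%; both lie beyond the scatter from compound 3, compound 1 nearest and compound 2 furthest. Within the data shown here, the single measured step, a number 3 percentage points higher from compound 1 to compound 2 (within the scatter), moves the nitrophenyl and says nothing about the part of the molecule changed here. Compound 4 `O=S(=O)(c1sccc1-c1ccccc1Oc1ccc(O)c(O)c1)N1CCN(C(=S)Nc2ccc(Cl)cc2)CC1` differs from compound 3 by 3,4-dihydroxyphenyl in place of 3,4-dimethoxyphenyl on an oxygen on an aromatic ring. Among the measured compounds shown here, compounds 1 and 2 carry the same 3,4-dihydroxyphenoxy as compound 4 but differ from compound 3 in more than one place, so their gap to compound 3 is no clean step for this change; it shows only that the two dihydroxy compounds measured read higher than the one dimethoxy compound. On that basis a rise is expected for compound 4, a number 10 percentage points higher from compound 3 to compound 4 (within the scatter), though with wide uncertainty. The estimate for compound 4 is 28%, ranging from 10% to 46%.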

Compound 4, a percentage reported as inhibition, at one concentration (the size of the read-out at that concentration, not a potency): 2%
Compound 4: the middle estimate sits 26 percentage points above what was measured; measured number below the stated range.
By their numbers in this assay, from the lowest: compound 4; then compound 3; then compounds 1 and 2 (each within the scatter of the next).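

In this assay, among these compounds, the one clean comparison at this position runs against the dihydroxy group: 3,4-dihydroxyphenyl in place of 3,4-dimethoxyphenyl on an oxygen on an aromatic ring gives a number 16 percentage points lower from compound 3 to compound 4 (beyond the scatter). With the 3,4-dihydroxyphenoxy held constant, changing the group on the amine nitrogen in a ring gives a number 31 percentage points lower from compound 2 to compound 4 (beyond the scatter) and a number 28 percentage points lower from compound 1 to compound 4 (beyond the scatter), so the higher numbers of compound 1 and compound 2 go with that group and not with the dihydroxy group alone. Nothing available gives a reason for either change.

Still open, as far as these compounds go, is whether the dimethoxy to dihydroxy step keeps its direction when the nitrophenyl groups of compound 1 and compound 2 sit on the amine nitrogen. Also open, from the compounds shown here alone, is how a single hydroxy group or a carboxylic acid on that aromatic ring would read.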